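The source may hold more compounds than are shown below. What is called first, only, known or untested is meant among the compounds shown, and "the series" means these compounds.

Measured so far: compound 1 `O=C1c2ccccc2N(Cc2ccccc2)S(=O)(=O)N1COCc1ccccc1`, compound 2 `O=C(OCCOCN1c2ccccc2C(=O)N(Cc2ccccc2)S1(=O)=O)c1ccccc1`, compound 3 `C#CCOCN1c2ccccc2C(=O)N(Cc2ccccc2)S1(=O)=O`.

In a functional assay on HEL cells (Homo sapiens) for cytotoxicity (a higher number here means that more compound is tolerated, a lower number that less compound is tolerated), compound 1 gives 20 ug/mL, the lowest of the three numbers. Compound 2 gives 50 ug/mL and compound 3 gives 50 ug/mL; the step of no change at the digits printed from compound 2 to compound 3 (within the scatter) alters only the chain and leaves the figure unchanged within the scatter.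

Compound 4 `O=C1c2ccccc2NS(=O)(=O)N1COCc1ccccc1` is obtained from compound 1 by hydrogen in place of benzyl on a sulfonamide nitrogen in a ring. Within the data shown here, no measured step touches the sulfonamide nitrogen, so nothing among the three compounds bears directly on this change; the only step known concerns the chain. The step from compound 1 to compound 4 is therefore expected to be small, a 1.5-fold higher number from compound 1 to compound 4 (0.18 log units; within the scatter), perhaps a slight rise. Compound 4 is estimated at 30 ug/mL, between 12 ug/mL and 75 ug/mL.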

Compound 4, minimum cytotoxic concentration: > 50 ug/mL
Compound 4 was reported as a limit; the forecaster's own chance of this, stated with the estimate: 25%; middle value at least 1.6-fold (0.22 log units) away from the limit.
By their numbers in this assay, from the lowest: compound 1; then compounds 2 and 3 (each within the scatter of the next).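

In this assay, among these compounds, hydrogen in place of benzyl on the sulfonamide nitrogen in the ring gives an at least 2.5-fold higher number from compound 1 to compound 4 (0.39 log units; beyond the scatter), the first reading on this position, as the earlier step touched only the chain. With the (benzyloxy)methyl group held fixed, more compound is tolerated with hydrogen on this nitrogen than with benzyl. Compound 4 stands as a limit, not a number: the limit of > 50 ug/mL in this assay, at which 1 of the 4 values shown sits.

On these data alone, whether the same change holds with the chains of compound 2 and compound 3 remains open. So does how a methyl group or a longer alkyl chain on this nitrogen would read.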